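A Halogen Swap at the Far End of a Weak Series

The source may report more compounds than this note shows. Statements on the series, on what has been measured and on what is new or still open speak of the compounds shown alone.

Compound 1, `Nc1c(C(=O)N/N=C/c2ccc(Br)cc2)oc2nc(-c3cccs3)cc(C(F)(F)F)c12`: 86000 nM
Compound 2, `Nc1c(C(=O)N/N=C/c2ccccc2)oc2nc(-c3ccccc3)cc(C(F)(F)F)c12`: 70000 nM
Compound 3, `CNC(=O)c1oc2nc(-c3ccccc3)cc(C(F)(F)F)c2c1N`: 62000 nM

All three were tested in an ADME assay on HEK293 cells (Homo sapiens) for antiproliferative activity, read by MTT assay; a lower number here means a stronger inhibitor, a higher number a weaker inhibitor. Compound 1 has the highest of the three numbers, but the gap to compound 2 and the gap to compound 3 are each within the usual scatter of this assay, so the three cannot be told apart on these data. For the measured compounds named here, the only step between compounds that differ in a single place is a 1.1-fold lower number from compound 2 to compound 3 (0.05 log units; within the scatter), a change on an amide-type nitrogen that left the number essentially where it was.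

Compound 4, `Nc1c(C(=O)N/N=C/c2ccc(Cl)cc2)oc2nc(-c3cccs3)cc(C(F)(F)F)c12`, is compound 1 with chloro in place of bromo on an aromatic carbon. Going by the values given here, no measured step touches this position; the one recorded step concerns a different part of the molecule and stayed within the scatter. With nothing in the data pointing to a change in either direction, compound 4 is expected to sit close to compound 1, with a 1.0-fold lower number from compound 1 to compound 4 (0.01 log units; within the scatter) as the expected step. The estimate for compound 4 is 85000 nM, expected to fall between 40000 nM and 180000 nM.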

Compound 4, half-maximal inhibitory concentration: 83000 nM
Compound 4: the middle estimate sits 1.0-fold (0.01 log units) above what was measured, within the range that was stated.
By their numbers in this assay, from the lowest: compounds 3, 2, 4 and 1 (each within the scatter of the next).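

The earlier compounds shown here gave no step at this position, and in this assay the first one there, chloro in place of bromo, gives a 1.0-fold lower number from compound 1 to compound 4 (0.02 log units; within the scatter) and stays within the scatter. On this aromatic carbon, para to a large group, these two halogens therefore cannot be told apart, so on these data the change from 4-bromophenyl to 4-chlorophenyl makes no readable difference. Nothing measured here offers an explanation for this result.

Only two halogens are compared at this position, so the result says nothing about how an amine, a carboxylic acid or a longer chain on the same carbon would read. From the compounds shown here alone, it also remains open whether fluoro, or plain hydrogen, would leave the number within the scatter of compound 1 or move it clearly beyond.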